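Compound 3: Removing One Methoxy Group from Compound 2

This account rests on a few compounds, and the source may have more. Where it says the series, first, only, none or still open, it means among the compounds named here.

Measured compounds:
compound 1 `COc1cc(Br)c(C2C(C#N)=C(N)OC(c3c[nH]c4ccccc34)=C2C#N)cc1OC` — 18.5%
compound 2 `COc1ccc(C2C(C#N)=C(N)OC(c3c[nH]c4ccccc34)=C2C#N)cc1OC` — 14.5%

In a functional assay, tested at 50 ug/mL (on this read-out lower numbers stand for a weaker effect and higher numbers for a stronger effect at the one concentration tested), compound 1 gives 18.5%. In this assay compound 2 gives 14.5%. Of the two numbers shown, that of compound 2 is the lower, but the difference a number 4 percentage points lower from compound 1 to compound 2 (within the scatter) lies within the scatter, so the two compounds cannot be told apart on this read-out.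

Compound 3 `COc1ccc(C2C(C#N)=C(N)OC(c3c[nH]c4ccccc34)=C2C#N)cc1` is not yet measured. It differs from compound 2 in one place: hydrogen in place of methoxy on an aromatic carbon. Cut one bond further out, the change reads 3,4-dimethoxyphenyl to 4-methoxyphenyl.

Going by the values given here, only one measured step bears on this, the one from compound 1 to compound 2, in which a substituent on the same six-membered aromatic ring was replaced by hydrogen and the read-out moved by a number 4 percentage points lower from compound 1 to compound 2 (within the scatter), within the scatter. That step concerns a bromo group, not a methoxy group, so it is an indirect guide at best. On that basis compound 3 is expected to show a step of a number 0.5 percentage points lower from compound 2 to compound 3 (within the scatter), that is none beyond the scatter. Compound 3 is therefore estimated at 14%, in the range 4% to 26%.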

Compound 3, a percentage reported as activity, at one concentration (the size of the read-out at that concentration, not a potency): 12.4%
Estimate against measurement, compound 3: 1.6 percentage points above; low and high end bracket the measured number.
By their numbers in this assay, from the lowest: compounds 3, 2 and 1 (each within the scatter of the next).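

Replacing the methoxy group by hydrogen, which turns 3,4-dimethoxyphenyl into 4-methoxyphenyl, gives in this assay a number 2.1 percentage points lower from compound 2 to compound 3 (within the scatter) and so does not separate the two compounds on this read-out. Going by these compounds alone, this is the first evidence on this position, the aromatic carbon ortho to a methoxy group and meta to a large group, and it shows that a methoxy group can give way to hydrogen there without a step beyond the scatter. Alongside a number 4 percentage points lower from compound 1 to compound 2 (within the scatter) in this assay, it makes two single replacements by hydrogen on this aromatic ring, a bromo group in one and a methoxy group in the other, neither of which moves the number beyond the scatter. No measurement offers an explanation for this result.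

The compounds shown carry only hydrogen or methoxy at this position, so it remains open whether an amine or a carboxylic acid there would give a step beyond the scatter. Going by these compounds, it also remains open whether replacing the remaining methoxy group of the 4-methoxyphenyl ring by hydrogen would leave the read-out within the scatter of compound 3.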